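The compounds below may be only part of what the source reports. "The series", "measured", "known", "first", "only" and "open" are said of these compounds alone.

Measured so far:
compound 1 `CC(=O)Nc1ccc(S(=O)(=O)NNC(=O)c2cccnc2Nc2ccc(Cl)cc2)cc1` — in a functional assay on SK-MEL-28 cells (Homo sapiens) for antiproliferative activity (on this read-out higher numbers stand for weaker inhibition of growth and lower numbers for stronger inhibition of growth), compound 1 gives > 100000 nM, which is a limit of the assay, not a number.
compound 2 `O=C(NNS(=O)(=O)c1ccc(F)cc1)c1cccnc1Nc1ccc(Cl)cc1Cl` — in this assay compound 2 gives > 100000 nM, likewise only a limit.

Compound 1 thus stands at the limit of > 100000 nM in this assay, at which 2 of the 2 values shown sit, and no number separates it from compound 2. Compound 3 `O=C(NNS(=O)(=O)c1ccc(Cl)cc1Cl)c1cccnc1Nc1ccc(Cl)cc1` carries 2,4-dichlorophenyl in place of 4-acetamidophenyl on a sulfonyl sulfur. Within the data shown here, no measured pair follows this change, so no size can be read from the series; in this assay the expectation is no movement beyond the scatter, with another limit the most likely outcome. Compound 3 is expected at 100000 nM (range 30000 nM to 300000 nM). The expected step of a number no higher from compound 1 to compound 3 (the limit leaves the size open) is essentially none.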

Compound 3, concentration for total growth inhibition: > 100000 nM
Compound 3: no number, only a limit; the forecaster's own chance of this, stated with the estimate: 80%; the middle value sits exactly at the limit.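

No new step can be read between compound 1 and compound 3, as each gives only a limit and no number: the limit of > 100000 nM in this assay, at which 3 of the 3 values shown sit.
In this assay the compounds shown leave open whether the group on the sulfonyl sulfur changes growth inhibition at all.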